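This account rests on a few compounds, and the source may have more. Where it says the series, first, only, none or still open, it means among the compounds named here.

Measured so far in a functional assay on MDA-MB-231 cells (Homo sapiens) for cytotoxicity, read by MTT assay, with a stated time of 24 h; a higher number here means a weaker inhibitor, a lower number a stronger inhibitor:
compound 1, `CCCCCCCCCCCC(=O)Nc1nnc(S[C@@H]2O[C@H](CO)[C@H](O)[C@H](O)[C@H]2O)s1`, 32000 nM
compound 2, `CCCCCCCCCC(=O)Nc1nnc(S[C@@H]2O[C@H](COC(C)=O)[C@H](OC(C)=O)[C@H](OC(C)=O)[C@H]2OC(C)=O)s1`, 19200 nM
compound 3, `CCCCCCCC(=O)Nc1nnc(S[C@@H]2O[C@H](COC(C)=O)[C@H](OC(C)=O)[C@H](OC(C)=O)[C@H]2OC(C)=O)s1`, 18900 nM

Compound 1 carries the highest of the three numbers, but its gap to compound 2 and its gap to compound 3 are both within the scatter, so the three compounds read as indistinguishable in this assay. Among the measured compounds shown here, the one single-point step among them, a 1.0-fold lower number from compound 2 to compound 3 (0.01 log units; within the scatter), shortens the saturated chain and leaves the number unchanged.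

Compound 4, `CCCCCCCC/C=C\CCCCCCCCCCCC(=O)Nc1nnc(S[C@@H]2O[C@H](CO)[C@H](O)[C@H](O)[C@H]2O)s1`, has not yet been measured. Against compound 1 the change is dec-1-en-1-yl in place of hydrogen on a saturated chain carbon, ten or more bonds along the chain from a carbonyl carbon. For the measured compounds named here, this is again a change of the saturated chain only, and the only measured step that bears on it is the chain shortening a 1.0-fold lower number from compound 2 to compound 3 (0.01 log units; within the scatter), which was flat. Going by the values given here, the present change is much larger and brings in a double bond, for which no step is on hand, so the expectation rests on that flat chain step alone and carries a wide range. The expected step is a 1.3-fold lower number from compound 1 to compound 4 (0.11 log units; within the scatter), none beyond the scatter. The estimate for compound 4 in this assay is 25000 nM, with a range from 8000 nM to 80000 nM.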

Compound 4, half-maximal inhibitory concentration: 70400 nM
Beside the measured number, compound 4's estimate is 2.8-fold (0.45 log units) below it, and the stated range covers the measured number.
By their numbers in this assay, from the lowest: compounds 3, 2 and 1 (each within the scatter of the next); then compound 4.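

In this assay, among the compounds shown here, a 2.2-fold higher number from compound 1 to compound 4 (0.34 log units; beyond the scatter) is the first step to lie beyond the scatter, so a change on a saturated chain carbon can move the number, whereas the shortening in a 1.0-fold lower number from compound 2 to compound 3 (0.01 log units; within the scatter) left it flat. The direction is toward a weaker inhibitor: at this position, dec-1-en-1-yl in place of hydrogen gives no gain, and the size of the step is modest. Nothing on hand explains the shift.

This step carries added chain length and a double bond together, and the compounds shown do not separate the two; a fully saturated chain of the same length, set on the core of compound 1, would do so. Also open, from the compounds shown here alone, is whether a chain ending in an amine or a carboxylic acid would follow the same direction as dec-1-en-1-yl, or whether the number responds to the far end of the chain only through its length.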